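Fluorine count on the benzyl group and cell tolerance

This account rests on a few compounds, and the source may have more. Where it says the series, first, only, none or still open, it means among the compounds named here.

Measured compounds:
compound 1, `CCOC(=O)/C(O)=C/C(=O)c1cn(Cc2cc(F)c(F)c(F)c2)c2cccc(OC)c12` — 33400 nM
compound 2, `CCOC(=O)/C(O)=C/C(=O)c1cn(Cc2ccc(F)c(F)c2)c2cccc(OC)c12` — 125000 nM
compound 3, `COc1cccc2c1c(C(=O)/C=C(\O)C(=O)O)cn2Cc1ccccc1F` — 70500 nM

In an ADME assay on MT4 cells (Homo sapiens) for cytotoxicity, read by MTT assay (a higher number here means that more compound is tolerated, a lower number that less compound is tolerated), compound 3 gives 70500 nM. Among the three measured numbers this is the second highest: the nearest is compound 2 at 125000 nM, and the two lie within the usual scatter of each other, so no order between them can be claimed. Compound 1, at 33400 nM, gives a lower number than compound 3 by a gap beyond the scatter.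

The unmeasured compound 4, `COc1cccc2c1c(C(=O)/C=C(\O)C(=O)O)cn2Cc1ccc(F)cc1F`, differs from compound 3 in one place: fluoro in place of hydrogen on an aromatic carbon.

Among the compounds with values here, only one measured step speaks to this kind of change, and it runs the opposite way. Removing a fluoro from an aromatic carbon gave a 3.7-fold higher number from compound 1 to compound 2 (0.57 log units; beyond the scatter), that is, a modestly higher number once the fluoro was gone. Turned around, adding a fluoro would be expected to lower the number by a similar modest amount, though those two compounds carry an ethyl ester where compound 3 carries the free acid.

For compound 4 the expectation in this assay is therefore a modestly lower number than compound 3, a step of about a 2.0-fold lower number from compound 3 to compound 4 (0.30 log units; within the scatter). Compound 4 is estimated at 35000 nM, with a likely range from 15000 nM to 90000 nM.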

Compound 4, half-maximal cytotoxic concentration: 20800 nM
Compound 4: middle estimate off by 1.7-fold (0.23 log units), on the high side; low and high end bracket the measured number.
By their numbers in this assay, from the lowest: compounds 4 and 1 (each within the scatter of the next); then compounds 3 and 2 (each within the scatter of the next).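

Within the data shown here, until now, the only step for adding a fluoro came from the ethyl ester pair, so it was unclear whether it would hold for a free carboxylic acid. Going from the 2-fluorobenzyl group to the 2,4-difluorobenzyl group in this assay gives a 3.4-fold lower number from compound 3 to compound 4 (0.53 log units; beyond the scatter), which shows that the drop in tolerance also appears on the acid core, with the new fluoro para to a large group. The size of the step also carries over, since removing a fluoro raises the number by a closely matching amount on both cores, a small but useful sign that the ester and the acid do not change the effect of this swap on the benzyl ring: the same change on two cores in this assay, a 3.7-fold higher number (0.57 log units; beyond the scatter) from compound 1 to compound 2 and a 3.4-fold higher number (0.53 log units; beyond the scatter) from compound 4 to compound 3, 1.1-fold (0.04 log units) apart, within the scatter of two such steps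

Two pairs are still a thin basis, and they do not reveal whether the drop depends on fluoro itself or would also follow a chloro, a methyl or a methoxy group in the same place. As far as these compounds go, it also remains open how an amine or a longer chain at this position would compare, and whether the ethyl ester of compound 4 would fit the same picture.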